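Methyl Added at a New Place: Expected Effect on Solubility

A few compounds are considered here, and "the series" means these few. Any claim that something is new, unique, unknown or untested is made for them only; others in the source may bear on it.

Compound 1 `CN(C)c1ccc(Nc2c(NCCCCCC(=O)NO)c(=O)c2=O)cc1`: 1400000 nM
Compound 2 `C[C@H](CCCCC(=O)NO)Nc1c(Nc2ccc(N(C)C)cc2)c(=O)c1=O`: 27000000 nM
Compound 3 `CCC(CCCCC(=O)NO)Nc1c(Nc2ccc(C(F)(F)F)cc2)c(=O)c1=O`: 25000000 nM

Of the compounds shown here, three have been measured in a physicochemical assay for solubility, with a stated time of 24 h, tested at 30 mg/mL (a higher number here means a more soluble compound, a lower number a less soluble compound), and a fourth, compound 4 `CC(C)C(CCCCC(=O)NO)Nc1c(Nc2ccc(C(F)(F)F)cc2)c(=O)c1=O`, awaits measurement. In this assay compound 1 gives 1400000 nM. Compound 2 differs from compound 1 by methyl in place of hydrogen on a saturated chain carbon bound to a nitrogen on an aromatic ring and a saturated chain carbon, and this change brings a 19-fold higher number from compound 1 to compound 2 (1.29 log units; beyond the scatter). Compound 3 gives 25000000 nM; its value and that of compound 2 lie within the scatter of each other, while compound 1 stands well below both. The difference between the cores of compound 1 and compound 3 is not broken down here.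

Compound 4 arises from compound 3 by methyl in place of hydrogen on a saturated chain carbon bound to two saturated chain carbons. Among the compounds with values here, this is the same kind of change as the one from compound 1 to compound 2, but not the same change: there the carbon receiving the methyl was bound to a nitrogen on an aromatic ring and a saturated chain carbon, whereas here it is bound to two saturated chain carbons. Within the data shown here, the earlier step of a 19-fold higher number from compound 1 to compound 2 (1.29 log units; beyond the scatter) is the only measured guide, and it was taken on a different core and at a different place. For compound 4 a step of a 1.7-fold lower number from compound 3 to compound 4 (0.22 log units; within the scatter) is expected, smaller than the earlier one, because compound 3 already gives 25000000 nM and the new methyl sits one bond further out along the chain. Compound 4 is therefore estimated at about 15000000 nM, with a likely range from 4000000 nM to 40000000 nM.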

Compound 4, solubility: 6300000 nM
Compound 4: middle estimate off by 2.4-fold (0.38 log units), on the high side, and the stated range covers the measured number.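

In this assay, methyl in place of hydrogen on a saturated chain carbon bound to two saturated chain carbons gives a 4.0-fold lower number from compound 3 to compound 4 (0.60 log units; beyond the scatter) in the new step, while methyl on a saturated chain carbon bound to a nitrogen on an aromatic ring and a saturated chain carbon gave a 19-fold higher number from compound 1 to compound 2 (1.29 log units; beyond the scatter) on the other core. The two steps therefore run in opposite directions, which shows that in this series the result of adding a methyl at one place on one core cannot simply be carried over to another place on another core. They do not show whether the core, the place or both set the outcome, since the two pairs differ in both and each is a single example, and nothing measured here bears on the reason for the result.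

The compounds shown leave open what the same methyl would do at the same place on the core of compound 1, which would separate the role of the core from that of the place. They also leave open whether a longer chain, such as a butyl group, or an amine at this carbon would follow compound 4 or go the other way.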